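Removing the acetyl ester from compound 3

The source may report more compounds than this note shows. Statements on the series, on what has been measured and on what is new or still open speak of the compounds shown alone.

Of the compounds shown here, three sharing one core have been tested in a functional assay on CCRF-CEM cells (Homo sapiens) for inhibition; on this read-out higher numbers stand for weaker inhibition and lower numbers for stronger inhibition. Compound 1 `CC(=O)OCCOn1cnc2c(S)nc(N)nc21` gives 7500 nM in this assay. Compound 3 `CC(=O)OCCOn1cnc2c(S)nc(F)nc21` carries fluoro in place of amino on an aromatic carbon and gives 37000 nM; the step is a 4.9-fold higher number from compound 1 to compound 3 (0.69 log units; beyond the scatter). For compound 2 `CC(=O)OC(C)n1cnc2c(S)nc(F)nc21` the assay reports only a limit, > 500000 nM (the limit of > 500000 nM in this assay, at which 1 of the 3 values shown sits). Among the two actual numbers, compound 3 thus stands highest, with compound 1 as its nearest neighbour and the gap between them beyond the usual scatter.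

Compound 4 `OCCOn1cnc2c(S)nc(F)nc21` keeps the fluoro-bearing core of compound 3 and differs only at the side chain: hydrogen in place of acetyl on an oxygen on a saturated carbon. For the measured compounds named here, no measured step touches this part of the molecule. The single step shown, from compound 1 to compound 3, alters the aromatic substituent and gives no guidance on what losing the acetyl group does. With nothing to point to a change in either direction, the expectation for compound 4 is a number close to that of compound 3, within the scatter. Compound 4 is therefore estimated at 40000 nM in this assay, with a range from 12000 nM to 150000 nM. The expected step is a 1.1-fold higher number from compound 3 to compound 4 (0.03 log units; within the scatter).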

Compound 4, half-maximal inhibitory concentration: 117000 nM
For compound 4 the middle estimate is 2.9-fold (0.47 log units) below the measured one, within the range that was stated.
By their numbers in this assay, from the lowest: compound 1; then compound 3; then compound 4. At a limit, above all of these: compound 2.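

The side chain is not a silent part of these molecules: in this assay, putting hydrogen in place of acetyl on the oxygen, which turns the 2-acetoxyethyl group into a 2-hydroxyethyl group, gives a 3.2-fold higher number from compound 3 to compound 4 (0.50 log units; beyond the scatter). For the compounds shown here, the only earlier step with a single change concerned the aromatic substituent, so this is the first measured sign that this oxygen of the chain matters for the read-out, and here the free hydroxy group goes with weaker inhibition than the acetoxy group. The step is modest, and nothing shown here accounts for the rise in the number.

Whether the same swap has a similar effect with amino in place of fluoro on the aromatic carbon, as in compound 1, remains an open question. On these data alone, it also remains open how other groups on this oxygen would compare with acetyl and hydrogen, such as a methyl ether, a benzoyl ester or a carbamate, and how a longer chain between this oxygen and the core would read out.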